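This account rests on a few compounds, and the source may have more. Where it says the series, first, only, none or still open, it means among the compounds named here.

Measured so far in a functional assay on A549 cells (Homo sapiens) for cytotoxicity, read by MTT assay, with a stated time of 24 h; a higher number here means a weaker inhibitor, a lower number a stronger inhibitor:
Compound 1 `CNC(=O)Cn1nc(N)c2c(C(F)(F)F)cc(-c3ccccc3)nc21`: 15300 nM
Compound 2 `CCCNC(=O)Cn1nc(N)c2c(C(F)(F)F)cc(-c3ccccc3)nc21`: 16500 nM
Compound 3 `NCCNC(=O)Cn1nc(N)c2c(C(F)(F)F)cc(-c3ccccc3)nc21`: 50200 nM

Compound 3 gives the highest number of the three in this assay. Both steps that lead to it, a 3.3-fold higher number from compound 1 to compound 3 (0.52 log units; beyond the scatter) and a 3.0-fold higher number from compound 2 to compound 3 (0.48 log units; beyond the scatter), are beyond the scatter, so among these three compound 3 is the weakest inhibitor. Compound 4 `Nc1nn(CC(=O)NC2CCCCC2)c2nc(-c3ccccc3)cc(C(F)(F)F)c12` is the compound that follows, and the change from compound 3 is cyclohexyl in place of 2-aminoethyl on an amide-type nitrogen. For the measured compounds named here, two measured steps bear on this change, since each ends with the 2-aminoethyl group that now leaves: a 3.3-fold higher number from compound 1 to compound 3 (0.52 log units; beyond the scatter) and a 3.0-fold higher number from compound 2 to compound 3 (0.48 log units; beyond the scatter), both modest. The third step, a 1.1-fold higher number from compound 1 to compound 2 (0.03 log units; within the scatter), lies within the scatter, and the values of compounds 1 and 2 sit within the scatter of each other. Compound 4 carries a group with no amine on the amide-type nitrogen, and is therefore expected to move back toward the numbers of compounds 1 and 2. For compound 4 the expected step in this assay is a 3.3-fold lower number from compound 3 to compound 4 (0.52 log units; beyond the scatter), a modest move toward a stronger inhibitor. Compound 4 is estimated at 15000 nM in this assay, with a range from 6000 nM to 40000 nM.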

Compound 4, half-maximal inhibitory concentration: 2300 nM
Beside the measured number, compound 4's estimate is 6.5-fold (0.81 log units) above it; the whole stated range lies above it.
By their numbers in this assay, from the lowest: compound 4; then compounds 1 and 2 (each within the scatter of the next); then compound 3.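

In this assay, for the compounds shown here, the group on the amide-type nitrogen turns out to be able to take the number well below the level of compounds 1 and 2, which the earlier compounds did not show: cyclohexyl gives a clear gain over methyl (a 6.7-fold lower number from compound 1 to compound 4 (0.82 log units; beyond the scatter)) and over propyl (a 7.2-fold lower number from compound 2 to compound 4 (0.86 log units; beyond the scatter)), which makes compound 4 the strongest inhibitor of the four. The change from 2-aminoethyl, an open chain with no ring, to a six-membered non-aromatic ring of carbon only is the largest step seen at this position (a 22-fold lower number from compound 3 to compound 4 (1.34 log units; beyond the scatter)), so this nitrogen tolerates much more change in the number than the methyl and propyl pair suggested. No accompanying measurement explains this gain.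

The compounds shown leave open whether the ring itself matters or only the number of carbons, a question that a cyclopentyl group, a phenyl group or an open hexyl chain on the same nitrogen would address. They also leave open whether an amine raises the number wherever it stands, as a cyclohexyl ring carrying an amine could show.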